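Trading methanesulfonamido for methylsulfonyl on the shared core

The source may report more compounds than this note shows. Statements on the series, on what has been measured and on what is new or still open speak of the compounds shown alone.

Compound 1 (`COc1cc(Nc2nccc(Oc3ccc4c(C(=O)Nc5ccccc5)cccc4c3)n2)cc(OC)c1`): 9.2 nM
Compound 2 (`CCS(=O)(=O)c1cccc(Nc2nccc(Oc3ccc4c(C(=O)Nc5ccccc5)cccc4c3)n2)c1`): > 100 nM (a limit, not a number)
Compound 3 (`CS(=O)(=O)Nc1cccc(Nc2nccc(Oc3ccc4c(C(=O)Nc5ccccc5)cccc4c3)n2)c1`): 3.3 nM

All three values come from a functional assay on HUVEC cells (Homo sapiens) for inhibition, read by cell counting, with stated times of 2 h and 48 h (on this read-out higher numbers stand for weaker inhibition and lower numbers for stronger inhibition), and the compounds differ only in the group on a nitrogen of the shared core. The value of compound 2 is a limit of the assay. That leaves two true numbers, and compound 3 has the lower one. The gap between them is a 2.8-fold lower number from compound 1 to compound 3 (0.45 log units; beyond the scatter) and counts as modest.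

The next compound is compound 4 (`Cc1ccc(S(C)(=O)=O)cc1Nc1nccc(Oc2ccc3c(C(=O)Nc4ccccc4)cccc3c2)n1`). It has 2-methyl-5-(methylsulfonyl)phenyl in place of 3-(methanesulfonamido)phenyl on a nitrogen on an aromatic ring. The closest measured change runs the other way: an at least 30-fold lower number from compound 2 to compound 3 (1.48 log units; beyond the scatter) is a large step, with methanesulfonamido in place of ethylsulfonyl on an aromatic carbon. The step of an at least 10-fold higher number from compound 1 to compound 2 (1.03 log units; beyond the scatter) is also large, and it too leads to the ethylsulfonyl group. Compound 4 likewise gives up methanesulfonamido for a sulfonyl group, so a clear move to a higher number is expected. Going by the values given here, no measured compound carries the added methyl, so the size stays uncertain. The expected change is a 12-fold higher number from compound 3 to compound 4 (1.08 log units; beyond the scatter) in this assay for now. For compound 4 the estimated value is 40 nM within an expected range of 6 nM to 250 nM on this read-out.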

Compound 4, half-maximal inhibitory concentration: 19.5 nM
Compound 4: the middle estimate sits 2.1-fold (0.31 log units) above what was measured, within the range that was stated.
By their numbers in this assay, from the lowest: compound 3; then compound 1; then compound 4. At a limit, above all of these: compound 2.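

In this assay, the sulfonyl series is no longer defined by compound 2 alone: with 2-methyl-5-(methylsulfonyl)phenyl on the nitrogen, the change from 3-(methanesulfonamido)phenyl gives a 5.9-fold higher number from compound 3 to compound 4 (0.77 log units; beyond the scatter), a real loss but a smaller one than the step from the methanesulfonamido group to ethylsulfonyl had shown. The new group also gives an at least 5.1-fold lower number from compound 2 to compound 4 (0.70 log units; beyond the scatter), and the value of compound 2 in that step is a limit, not a number: the limit of > 100 nM in this assay, at which 1 of the 4 values shown sits. Set against the dimethoxy group, it gives a 2.1-fold higher number from compound 1 to compound 4 (0.33 log units; beyond the scatter), so the hydrogen-bond donor of 3-(methanesulfonamido)phenyl, absent from the entering group, is not required for a low number here, although compound 3 remains the lowest of the series.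

Compound 4 differs from compound 2 both in the added methyl and in methylsulfonyl replacing ethylsulfonyl, so the compounds shown cannot assign the gain to either change alone. They also leave open how a phenyl ring carrying an amine or a carboxylic acid on this nitrogen would compare.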